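The compounds below may be only part of what the source reports. "The series", "measured", "known", "first", "only" and "open" are said of these compounds alone.

Of the compounds shown here, two sharing one core have been measured so far in an ADME assay on the whole organism (strain 129/SvEvBrd x C57BL/6) for metabolic stability, with Mus musculus as the target; on this read-out lower numbers stand for a shorter-lived compound and higher numbers for a longer-lived compound. Compound 1 `CC(O)c1nc([C@@H](O)[C@H](O)[C@H](O)CO)c[nH]1` gives 4.4 h, and compound 2 `CC(=O)N/N=C(\C)c1nc([C@@H](O)[C@H](O)[C@H](O)CO)c[nH]1` gives 2.6 h. These numbers lie within the usual scatter of each other, so compound 1 cannot yet be told apart from compound 2. Compound 3 `OC[C@@H](O)[C@@H](O)[C@H](O)c1c[nH]c(-c2ncc[nH]2)n1` keeps the core of compound 1 and carries a single change: 1H-imidazol-2-yl in place of 1-hydroxyethyl on an aromatic carbon. In words, this is 1H-imidazol-2-yl in place of 1-hydroxyethyl on an aromatic carbon. Among the measured compounds shown here, no measured pair differs in just one place, so the data offer no direct guide to this step in this assay. No shift beyond the scatter is therefore expected in either direction. The estimated change is a 1.5-fold lower number from compound 1 to compound 3 (0.17 log units; within the scatter), which would stay within the scatter. The expected half-life of compound 3 is 3 h, with an estimated range of 1.2 h to 7 h.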

Compound 3, half-life: 3.2 h
Beside the measured number, compound 3's estimate is 1.1-fold (0.03 log units) below it; low and high end bracket the measured number.
By their numbers in this assay, from the lowest: compounds 2, 3 and 1 (each within the scatter of the next).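

Putting 1H-imidazol-2-yl in place of 1-hydroxyethyl on this aromatic carbon, between two ring nitrogen atoms, gives a 1.4-fold lower number from compound 1 to compound 3 (0.14 log units; within the scatter) in this assay. Among the compounds shown here, this is the first measured pair that differs in one place, and it shows that at this position an open side group and a five-membered aromatic ring cannot be told apart on this read-out. No measurement shown here offers an explanation for this result.

On these data alone, it remains open whether a quite different group at this position, such as a carboxylic acid or a simple amine, would give a step beyond the scatter. Also open, as far as these compounds go, is how the half-life responds to a change in the group of 8 heavy atoms, which is the same in compound 1 and compound 3.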